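The source may hold more compounds than are shown below. What is called first, only, known or untested is meant among the compounds shown, and "the series" means these compounds.

Three compounds of one series share a core and differ only in the aryl group on an aromatic nitrogen. Compound 1 `Cc1cc(=O)n(-c2ccccc2OC(F)(F)F)nc1C(=O)Nc1ccc(Oc2ncnc3c2ccn3C)cc1` carries 2-(trifluoromethoxy)phenyl there. In a functional assay on HepG2 cells (Homo sapiens) for cytotoxicity, read by MTT assay, with a stated time of 72 h (on this read-out higher numbers stand for weaker inhibition and lower numbers for stronger inhibition), compound 1 gives only a limit, > 60000 nM. Compound 2 `Cc1cc(=O)n(-c2ccc(Br)cc2F)nc1C(=O)Nc1ccc(Oc2ncnc3c2ccn3C)cc1` carries 4-bromo-2-fluorophenyl, and in this assay compound 2 gives 33600 nM. Compound 3 `Cc1cc(=O)n(-c2cccc(F)c2)nc1C(=O)Nc1ccc(Oc2ncnc3c2ccn3C)cc1` carries 3-fluorophenyl. In this assay compound 3 likewise gives only a limit, > 60000 nM. The step of an at least 1.7-fold higher number from compound 2 to compound 3 (0.25 log units; that floor lies within the scatter) therefore rests on a floor inside the usual scatter, and the step that the two limits leave unreadable from compound 1 to compound 3 cannot be read, both values being the limit (the limit of > 60000 nM in this assay, at which 2 of the 3 values shown sit). So far, then, compound 3 stands at the limit together with compound 1, while compound 2 is the one member reported as a number.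

Compound 4 `Cc1ccc(-n2nc(C(=O)Nc3ccc(Oc4ncnc5c4ccn5C)cc3)c(C)cc2=O)cc1` is the next member: 4-methylphenyl in place of 3-fluorophenyl on an aromatic nitrogen. For the measured compounds named here, no measured step swaps a fluorine-bearing aryl for a methyl-bearing one, so the only guide is that every change of this aryl group so far has left the number at or near the limit. Compound 4 is therefore expected to give roughly 60000 nM, between 25000 nM and 150000 nM, most likely again as a limit. The expected step of a number no higher from compound 3 to compound 4 (the limit leaves the size open) is estimated to lie within the scatter.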

Compound 4, half-maximal inhibitory concentration: 33800 nM
The estimate for compound 4 lay 1.8-fold (0.25 log units) above the measured number, and the stated range covers the measured number.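

With compound 4, this assay gives a second number rather than a limit, so a number at this position does not depend on the halogens of 4-bromo-2-fluorophenyl: 4-methylphenyl, which holds carbon only, gives one too. The two groups cannot be told apart here, with a 1.0-fold higher number from compound 2 to compound 4 (0.00 log units; within the scatter), which means that the bromine and fluorine of compound 2 and the methyl group of compound 4 leave the read-out in the same place. The steps of an at least 1.7-fold lower number from compound 3 to compound 4 (0.24 log units; that floor lies within the scatter) and an at least 1.7-fold lower number from compound 1 to compound 4 (0.24 log units; that floor lies within the scatter) rest only on floors inside the scatter, so neither establishes a real gain for 4-methylphenyl, and the values they start from are limits: the limit of > 60000 nM in this assay, at which 2 of the 4 values shown sit.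

Every group shown on this nitrogen is a substituted phenyl, so what an amine, a carboxylic acid or a longer alkyl chain on that ring would give in this assay remains open. Also open is whether any change of this aryl group can move the number beyond the scatter, as no readable step among these four compounds does so.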